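This account rests on a few compounds, and the source may have more. Where it says the series, first, only, none or still open, it means among the compounds named here.

Of the compounds shown here, three of one series have been tested in a functional assay on Molt4/C8 cells (Homo sapiens) for inhibition; a lower number here means a stronger inhibitor, a higher number a weaker inhibitor. Compound 1 `O=C1/C(=C/c2ccccc2F)Cc2ccccc21` gives 54200 nM in this assay. Compound 2 `O=C1/C(=C/c2ccccc2Br)CCc2ccccc21` gives 36800 nM, and compound 3 `O=C1/C(=C/c2ccccc2Cl)CCCc2ccccc21` gives 37100 nM. Compound 1 holds the highest of these three numbers, yet its gaps to compound 2 and to compound 3 both fall within the usual scatter of this assay, so no order among the three can be read from them.

The step now followed leads from compound 1 to compound 4 `O=C1/C(=C/c2ccccc2Br)Cc2ccccc21`, which is not yet measured. The change is bromo in place of fluoro on an aromatic carbon. Among the compounds with values here, no step between two measured compounds isolates this exchange on the shared core of compound 1. Compound 2 carries a bromo group on a larger core and sits close to compound 1, which gives no sign of a shift beyond the scatter. The step from compound 1 to compound 4 is therefore expected to be a 1.3-fold lower number from compound 1 to compound 4 (0.11 log units; within the scatter), not beyond the scatter. Compound 4 is estimated at 42000 nM, within 15000 nM to 110000 nM.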

Compound 4, half-maximal inhibitory concentration: 95400 nM
Compound 4: the middle estimate sits 2.3-fold (0.36 log units) below what was measured; the range from low to high includes it.
By their numbers in this assay, from the lowest: compounds 2, 3, 1 and 4 (each within the scatter of the next, the first and the last beyond it).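

Within the data shown here, compound 4 gives the first direct reading of a halogen exchange on the shared core: with bromo in place of fluoro on an aromatic carbon, ortho to a large group, the step is a 1.8-fold higher number from compound 1 to compound 4 (0.25 log units; within the scatter), so this exchange at this position does not shift the result in this assay beyond the scatter. The two bromo compounds, however, are further apart: compound 2, on the larger core, gives 36800 nM and compound 4 gives 95400 nM, a gap beyond the scatter and the only one in the series. Nothing available accounts for either result.

The compounds shown leave open whether a group other than a halogen, such as an amine or a methoxy group, would shift the number beyond the scatter at this position on the shared core. They also leave open whether the gap between the two bromo compounds would recur with fluoro on both cores.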